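One Group Exchanged on a High-Number Compound

The compounds below may be only part of what the source reports. "The series", "measured", "known", "first", "only" and "open" are said of these compounds alone.

In a functional assay on NCI-H146 cells (Homo sapiens) for cytotoxicity, with a stated time of 48 h, in the presence of a further agent that is not named here (on this read-out higher numbers stand for an effect only at larger amounts of compound and lower numbers for an effect already at smaller amounts), compound 1 (`CN(C)CC[C@H](CSc1ccccc1)Nc1ccc(S(=O)(=O)NC(=O)c2ccc(N3CCN(Cc4ccccc4-c4ccc(Cl)cc4)CC3)cc2)cc1S(C)(=O)=O`) gives 34900 nM. This is the higher of the two numbers available, and compound 2 (`CN(C)CC[C@H](CSc1ccccc1)Nc1ccc(S(=O)(=O)NC(=O)c2ccc(N3CCN(CC4=C(c5ccc(Cl)cc5)CCCC4)CC3)cc2)cc1[N+](=O)[O-]`) gives 25.7 nM, a gap well beyond the scatter. Compound 2 differs from compound 1 in more than one place, however, so this pair cannot isolate the effect of any single change. Compound 3 (`CN(C)CC[C@H](CSc1ccccc1)Nc1ccc(S(=O)(=O)NC(=O)c2ccc(N3CCN(Cc4ccccc4-c4ccc(Cl)cc4)CC3)cc2)cc1C(=O)C(F)(F)F`) keeps the rest of compound 1 but carries (trifluoromethyl)carbonyl in place of methylsulfonyl on an aromatic carbon. Among the measured compounds shown here, no measured pair tests this exchange, so any forecast is loose. With compound 1 at 34900 nM and compound 2 at 25.7 nM, there is far more room for a fall than for a rise. The expected change is a 12-fold lower number from compound 1 to compound 3 (1.07 log units; beyond the scatter), toward a lower number and beyond the scatter. Compound 3 is estimated at 3000 nM, with an expected range from 300 nM to 30000 nM.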

Compound 3, half-maximal effective concentration: 2010 nM
For compound 3 the middle estimate is 1.5-fold (0.17 log units) above the measured one, and the stated range covers the measured number.
By their numbers in this assay, from the lowest: compound 2; then compound 3; then compound 1.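

Exchanging methylsulfonyl for (trifluoromethyl)carbonyl on this one aromatic carbon, with the rest of the structure kept, gives a 17-fold lower number from compound 1 to compound 3 (1.24 log units; beyond the scatter) in this assay. Among the compounds shown here, this is the first comparison here that isolates a single change, and it shows that this position, ortho to a large group, is sensitive to the group it carries: one exchange alone moves the number beyond the scatter. No measurement is available that accounts for this shift.

From the compounds shown here alone, it remains open whether the lower number is specific to (trifluoromethyl)carbonyl or would also follow other replacements of methylsulfonyl on the same carbon, such as a nitrile, an amine or a carboxylic acid. Also open, going by these compounds, is whether the same exchange gives a step of similar size when the rest of the molecule differs.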